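Cyclohexyl for cyclopropyl on the alkyne: cytotoxicity outlook

A few compounds are considered here, and "the series" means these few. Any claim that something is new, unique, unknown or untested is made for them only; others in the source may bear on it.

Measured compounds:
compound 1, `CCCCC#Cc1cn([C@@H]2O[C@H](CO)[C@@H](O)[C@H]2O)c(=O)[nH]c1=O`, 83200 nM
compound 2, `O=c1[nH]c(=O)n([C@@H]2O[C@H](CO)[C@@H](O)[C@H]2O)cc1C#CC1CC1`, 115000 nM
compound 3, `O=c1[nH]cc(C#Cc2ccccc2)c(=O)[nH]1`, 248000 nM

In an ADME assay on A549 cells (Homo sapiens) for cytotoxicity, read by MTT assay (a lower number here means that less compound is tolerated, a higher number that more compound is tolerated), compound 2 stands second highest of the three numbers. Its nearest neighbour is compound 1, and the step of a 1.4-fold higher number from compound 1 to compound 2 (0.14 log units; within the scatter) lies within the scatter, so the two cannot be told apart. For the measured compounds named here, the furthest is compound 3, whose value in this assay is 248000 nM; no single-point step links it to compound 2, so only the two values themselves can be compared.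

Compound 4, `O=c1[nH]c(=O)n([C@@H]2O[C@H](CO)[C@@H](O)[C@H]2O)cc1C#CC1CCCCC1`, differs from compound 2 in one place: cyclohexyl in place of cyclopropyl on a triple-bonded carbon. Going by the values given here, the only measured step that bears on this change is the one from compound 1 to compound 2, which swapped a butyl chain for a cyclopropyl ring on the same triple-bonded carbon and gave a 1.4-fold higher number from compound 1 to compound 2 (0.14 log units; within the scatter), a difference within the scatter. Among the compounds with values here, no measured step covers a six-membered ring at this position, so the expectation rests on that single step alone. Compound 4 is therefore expected to remain near compound 2, with the step of a 1.3-fold lower number from compound 2 to compound 4 (0.11 log units; within the scatter) not beyond the scatter. For compound 4 in this assay the estimated value is 90000 nM, within a range from 45000 nM to 180000 nM.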

Compound 4, half-maximal cytotoxic concentration: 127000 nM
Estimate against measurement, compound 4: 1.4-fold (0.15 log units) below; measured number inside the range.
By their numbers in this assay, from the lowest: compounds 1, 2, 4 and 3 (each within the scatter of the next, the first and the last beyond it).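

In this assay, putting cyclohexyl in place of cyclopropyl on the triple-bonded carbon gives a 1.1-fold higher number from compound 2 to compound 4 (0.04 log units; within the scatter), so a six-membered ring of 6 carbon atoms cannot be told apart from a three-membered ring of 3 carbon atoms at this position. The comparison with the open chain gives a 1.5-fold higher number from compound 1 to compound 4 (0.18 log units; within the scatter), which extends what the earlier step showed for butyl and cyclopropyl alone: on the shared core, all three groups on this carbon fall within the scatter of one another, and none of the three compounds goes against this. No evidence at hand explains why these changes leave the number indistinguishable.

What the compounds leave open is whether a group of another kind on this carbon, such as an amine or a carboxylic acid, would stay within the same scatter, as cyclopropyl and cyclohexyl both carry no hydrogen-bond donors or acceptors. From the compounds shown here alone, compound 3 differs from the other three in more than one place, so the effect of a phenyl group on this carbon of the shared core also remains open.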